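The source may hold more compounds than are shown below. What is called first, only, known or untested is meant among the compounds shown, and "the series" means these compounds.

Measured in a functional assay on OVCAR-5 cells (Homo sapiens) for inhibition, with a stated time of 48 h, tested at 50 uM; on this read-out higher numbers stand for more inhibition of growth at the one concentration tested and lower numbers for less inhibition of growth:

- compound 1 `C=C[C@@](C)(/C=C/c1ccc(OC(=O)CC)cc1)CCC=C(C)C`: 52%
- compound 2 `C=C[C@@](C)(/C=C/c1ccc(OC(=O)CCCCCCCCC)cc1)CCC=C(C)C`: 42%

For the measured compounds named here, only these two compounds have numbers so far, and they differ only in the length of one chain. Going by the values given here, compound 1 cannot be told apart from compound 2, its only measured neighbour, since the step is a number 10 percentage points lower from compound 1 to compound 2 (within the scatter).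

The next compound is compound 3 `C=C[C@@](C)(/C=C/c1ccc(OC)cc1)CCC=C(C)C`, which has not yet been measured. Its change from compound 1 is methyl in place of propanoyl on an oxygen on an aromatic ring. In words, this is methyl in place of propanoyl on an oxygen on an aromatic ring, or propanoyloxy to methoxy.

Among the compounds with values here, only one measured step bears on this change, and it bears only loosely. That step lengthens the chain but keeps the carbonyl, whereas compound 3 loses the carbonyl altogether. Within the data shown here, no measured pair shows that exact swap, so the direction remains open. Among the measured compounds shown here, the one step available, a number 10 percentage points lower from compound 1 to compound 2 (within the scatter), gives no sign that this part of the molecule moves the number much.

In this assay the expected change is therefore small, an estimated a number 4 percentage points lower from compound 1 to compound 3 (within the scatter), with none foreseen beyond the scatter.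

For compound 3 the estimated value is 48%, with an expected range from 28% to 68%.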

Compound 3, percent growth inhibition at one concentration: 37%
For compound 3 the middle estimate is 11 percentage points above the measured one, within the range that was stated.
By their numbers in this assay, from the lowest: compounds 3, 2 and 1 (each within the scatter of the next, the first and the last beyond it).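

In this assay, putting methyl in place of propanoyl on an oxygen on an aromatic ring gives a number 15 percentage points lower from compound 1 to compound 3 (beyond the scatter) and so shows that this position can move the number beyond the usual spread of repeats. The earlier change at the far end of the same ester chain, a number 10 percentage points lower from compound 1 to compound 2 (within the scatter) by comparison, could not show this, since it kept the carbonyl and only lengthened the chain. Here the propanoyl, with its carbonyl and its one hydrogen-bond acceptor, leaves altogether, but no accompanying measurement explains the lower number.

For the compounds shown here, with only this swap in hand, the loss of the carbonyl cannot be separated from the shortening of the group on the oxygen. From the compounds shown here alone, an acetyl group on that oxygen would keep the carbonyl in a shorter group, whereas an ethyl or propyl group would lack the carbonyl at a length nearer to that of propanoyl, and a free hydroxyl would leave the oxygen with no group at all, so how any of these would read remains open.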